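The compounds below may be only part of what the source reports. "The series", "measured", "known", "first", "only" and "open" are said of these compounds alone.

Measured compounds in a functional assay on KB-V1 cells (Homo sapiens) for cytotoxicity, read by MTT assay, with a stated time of 72 h (a higher number here means a weaker inhibitor, a lower number a stronger inhibitor), are these:
- compound 1 `C=CCNC(=S)N/N=C1\C(=O)Nc2ccccc21` gives 20700 nM here
- compound 2 `CNC(=S)N/N=C1\C(=O)Nc2ccccc21` gives 19400 nM here

On these numbers, compound 2 stands level with compound 1, the two values lying within the scatter of each other. The next compound is compound 3 `O=C1Nc2ccccc2/C1=N/NC(=S)Nc1cccc(Cl)c1` and its change from compound 2 is 3-chlorophenyl in place of methyl on an amide-type nitrogen which amounts to 3-chlorophenyl in place of methyl on an amide-type nitrogen.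

Within the data shown here, only one measured step bears on this change, namely a 1.1-fold lower number from compound 1 to compound 2 (0.03 log units; within the scatter) and it is small, an edit within an open chain. Among the measured compounds shown here, no measured compound carries a ring on that nitrogen, so this step cannot fix the size of a much larger exchange. A step beyond the scatter towards a lower number in this assay is nevertheless expected, as a judgement resting on thin data, and the range is kept wide. The expected change is a 4.9-fold lower number from compound 2 to compound 3 (0.69 log units; beyond the scatter) as estimated here. The estimated value for compound 3 is 4000 nM with an expected range of 1300 nM to 12000 nM for the measurement.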

Compound 3, half-maximal inhibitory concentration: 640 nM
Estimate against measurement, compound 3: 6.3-fold (0.80 log units) above, and the stated range ends above it.
By their numbers in this assay, from the lowest: compound 3; then compounds 2 and 1 (each within the scatter of the next).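

On the amide-type nitrogen whose other neighbour is the thiocarbonyl carbon, putting 3-chlorophenyl in place of methyl gives a 30-fold lower number from compound 2 to compound 3 (1.48 log units; beyond the scatter) in this assay, and putting it in place of allyl gives a 32-fold lower number from compound 1 to compound 3 (1.51 log units; beyond the scatter). The earlier pair, with only the two small open chains on this nitrogen, had left open whether the position could change the read-out at all; the aromatic group now shows that it can, and compound 3 is the strongest inhibitor of the three shown. The two steps are close in size, as expected from two starting compounds that stand level with each other, but no measured property of the compounds accounts for the size of the change.

The step exchanges a small chain for a chlorinated aromatic ring in one move, so it does not separate what the ring contributes from what the chlorine contributes, and a plain phenyl on this nitrogen would be needed to tell these apart. How far the result depends on where the chlorine stands, or on a direct link between ring and nitrogen, would take a 4-chlorophenyl and a benzyl group at the same place to show.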